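The source may report more compounds than this note shows. Statements on the series, on what has been measured and on what is new or still open speak of the compounds shown alone.

In an assay on isolated protein for inhibition of alpha-ketoglutarate-dependent dioxygenase alkB homolog 3 (Homo sapiens), read by polymerase chain reaction, with a stated time of 1 h (a higher number here means a weaker inhibitor, a lower number a stronger inhibitor), compound 1, `Cc1[nH]n(-c2ccccn2)c(=O)c1C`, gives only a limit of the assay, > 10000 nM, and not a number. Going by the values given here, compound 2, `Cc1[nH]n(-c2nc3cc(C(C)(C)C)ccc3[nH]2)c(=O)c1Cc1ccccc1`, is the one compound of the two with a measured value in this assay, giving 640 nM. That is where compound 2 stands among the figures shown: it holds the only number, while the other figure is the limit of > 10000 nM in this assay, at which 1 of the 2 values shown sits.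

Compound 3, `Cc1[nH]n(-c2nc3cc(C(F)(F)F)ccc3[nH]2)c(=O)c1Cc1ccccc1`, has not yet been measured in this assay. It differs from compound 2 in one place: trifluoromethyl in place of tert-butyl on an aromatic carbon. Among the compounds with values here, no step between measured compounds tells how this assay answers such a swap, so the expected direction rests on the change itself rather than on any measured pair. The step from compound 2 to compound 3 is expected to be small, at most a modest weakening, and quite possibly to stay within the usual scatter of repeated measurements, as a 1.7-fold higher number from compound 2 to compound 3 (0.24 log units; within the scatter) expresses. Compound 3 is therefore estimated to give about 1100 nM in this assay, with a range from 350 nM to 3500 nM.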

Compound 3, half-maximal inhibitory concentration: 610 nM
Estimate against measurement, compound 3: 1.8-fold (0.26 log units) above; low and high end bracket the measured number.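

In this assay, trifluoromethyl in place of tert-butyl on this aromatic carbon gives a 1.0-fold lower number from compound 2 to compound 3 (0.02 log units; within the scatter), so the read-out does not separate the two groups at this position. The groups match in the counts computed for them, with 4 heavy atoms, no ring, no hydrogen-bond donors or acceptors and no net charge, but differ in their atoms, 4 carbon against 1 carbon and 3 fluorine, and that exchange of atoms leaves the number within the scatter. Compound 1 differs from the other two compounds in more than one place, so its figure, which remains a limit and not a number, gives no step to set beside this one: the limit of > 10000 nM in this assay, at which 1 of the 3 values shown sits.

The compounds shown leave open what a group of another kind would do on this aromatic carbon, such as an amine, a carboxylic acid or a longer chain, since both groups seen here carry no hydrogen-bond donor or acceptor and have the same heavy-atom count. They also leave open whether a plain hydrogen at this carbon would give a number like those of compound 2 and compound 3 or one nearer the limit.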